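The source may hold more compounds than are shown below. What is called first, only, known or untested is meant among the compounds shown, and "the series" means these compounds.

Measured in a functional assay on KM12 cells (Homo sapiens) for cytotoxicity, read by sulforhodamine B assay, with a stated time of 48 h, tested at 100 uM; a higher number here means a weaker effect of the compound at the concentration tested, a lower number a stronger effect:
compound 1 `COc1cc(-c2cc(/C=C/C(=O)c3ccc(N)cc3)[nH]n2)cc(OC)c1OC` gives -79%;
compound 2 `COc1cc(-c2cc(/C=C/C(=O)c3ccc(Cl)c(Cl)c3)[nH]n2)cc(OC)c1OC` gives 3%;
compound 3 `COc1ccc(C(=O)/C=C/c2cc(-c3cc(OC)c(OC)c(OC)c3)n[nH]2)cc1OC` gives -75%.

Compound 3 stands second highest of the three numbers; its gap to compound 1 lies within the scatter, and the remaining step lies beyond it: a number 78 percentage points lower from compound 2 to compound 3 (beyond the scatter). Compound 4 `COc1ccc(C(=O)/C=C/c2cc(-c3cc(OC)c(OC)c(OC)c3)n[nH]2)cc1` differs from compound 3 by hydrogen in place of methoxy on an aromatic carbon. Going by the values given here, no measured step removes a methoxy; the steps that bear on it all exchange the aryl on the carbonyl carbon: a number 4 percentage points higher from compound 1 to compound 3 (within the scatter), whereas a number 82 percentage points higher from compound 1 to compound 2 (beyond the scatter). A change on this aryl can therefore be large or negligible, so a step of modest size toward a weaker effect, or none beyond the scatter, is expected in this assay. Compound 4 is estimated at -60% (range -95% to 5%), which corresponds to an expected step of a number 15 percentage points higher from compound 3 to compound 4 (beyond the scatter).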

Compound 4, a percentage reported as activity, at one concentration (the size of the read-out at that concentration, not a potency): -74%
Estimate against measurement, compound 4: 14 percentage points above, and the stated range covers the measured number.
By their numbers in this assay, from the lowest: compounds 1, 3 and 4 (each within the scatter of the next); then compound 2.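

In this assay, going by these compounds alone, the exchange of 3,4-dimethoxyphenyl for 4-methoxyphenyl is the first measured removal of a methoxy from this ring, and it gives a number 1 percentage points higher from compound 3 to compound 4 (within the scatter), so this methoxy is not required for the effect at the concentration tested. With methoxy in place of amino, a number 5 percentage points higher from compound 1 to compound 4 (within the scatter), so compound 4 does not separate from compound 1 either. With 4-methoxyphenyl in place of 3,4-dichlorophenyl, a number 77 percentage points lower from compound 2 to compound 4 (beyond the scatter), which leaves compound 2 alone apart from the other three.

A hydroxyl or a single chlorine on this ring, or hydrogen in place of the remaining methoxy, stays untested in the compounds shown. Nothing available accounts for these results.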